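A few compounds are considered here, and "the series" means these few. Any claim that something is new, unique, unknown or untested is made for them only; others in the source may bear on it.

Measured so far:

Compound 1 `Cc1ccc(-n2nccn2)c(C(=O)N2C[C@H](/C=C/c3ccc(F)cn3)CC[C@H]2C)c1` — in an assay on cells for binding affinity to Orexin receptor type 2 (Homo sapiens), read by radioligand binding (a lower number here means a stronger inhibitor, a higher number a weaker inhibitor), compound 1 gives 3 nM.
Compound 2 `Cc1ccc(-n2nccn2)c(C(=O)N2C[C@H](C#Cc3cncc(CO)c3)CC[C@H]2C)c1` — compound 2 gives 32 nM.
Compound 3 `Cc1ccc(-n2nccn2)c(C(=O)N2C[C@H](C#Cc3cccnc3O)CC[C@H]2C)c1` — compound 3 gives 24 nM.

Among these three numbers compound 3 stands second highest. Its nearest neighbour is compound 2, and the gap a 1.3-fold lower number from compound 2 to compound 3 (0.12 log units; within the scatter) is too small to mean anything. Its furthest neighbour is compound 1, and the gap an 8.0-fold higher number from compound 1 to compound 3 (0.90 log units; beyond the scatter) is a real one.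

Compound 4 `Cc1ccc(-n2nccn2)c(C(=O)N2C[C@H](/C=C\c3ccc(F)cn3)CC[C@H]2C)c1` has not yet been measured. It differs from compound 3 by 2-(5-fluoropyridin-2-yl)ethenyl in place of 2-(2-hydroxypyridin-3-yl)ethynyl on a saturated ring carbon. This brings back the same kind of side group that compound 1 carries, although the structures of compound 1 and compound 4 are not drawn identically around the double bond. The step that bears most directly on this change is the reverse of an 8.0-fold higher number from compound 1 to compound 3 (0.90 log units; beyond the scatter), and an 11-fold higher number from compound 1 to compound 2 (1.03 log units; beyond the scatter) points the same way: the ethenyl-linked fluoropyridine went with a clearly lower number than either ethynyl-linked pyridine. A step of about that size downward is therefore expected in this assay, tempered by the uncertainty that the differently drawn double bond brings, giving a 3.0-fold lower number from compound 3 to compound 4 (0.48 log units; beyond the scatter). Compound 4 is thus estimated at 8 nM, with a range from 2 nM to 40 nM.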

Compound 4, inhibition constant: 28 nM
For compound 4 the middle estimate is 3.5-fold (0.54 log units) below the measured one; the range from low to high includes it.
By their numbers in this assay, from the lowest: compound 1; then compounds 3, 4 and 2 (each within the scatter of the next).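

In this assay, the geometry of the double bond on this saturated ring carbon carries a real step, a 9.3-fold higher number from compound 1 to compound 4 (0.97 log units; beyond the scatter), and that step goes with a single difference: the fact that compounds 1 and 4 differ only in the configuration as drawn. The 2-(5-fluoropyridin-2-yl)ethenyl group therefore does not go with a low number on its own, since with the double bond drawn Z the results are a 1.2-fold higher number from compound 3 to compound 4 (0.07 log units; within the scatter) and a 1.1-fold lower number from compound 2 to compound 4 (0.06 log units; within the scatter). Among these four compounds, only compound 1, with its double bond drawn E, stands apart from the rest.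

On these data alone, it remains open whether the 2-hydroxypyridin-3-yl or 5-(hydroxymethyl)pyridin-3-yl group would also give a low number on an E double bond. The compounds shown also leave open what an ethynyl or a saturated ethyl link would do when carrying the 5-fluoropyridin-2-yl group.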